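Urea to Amide on a Shared Pyrazole Core

The compounds below may be only part of what the source reports. "The series", "measured", "known", "first", "only" and "open" are said of these compounds alone.

Three compounds share one core and were read in a functional assay on BT-549 cells (Homo sapiens) for inhibition, read by sulforhodamine B assay, with a stated time of 48 h, tested at 100 uM; a lower number here means a stronger effect, a higher number a weaker effect of the compound at the concentration tested. Compound 3, `COc1cc(Cl)cc(-c2nn(-c3cccc(NC(=O)Nc4ccc(Cl)c(Cl)c4)c3)cc2-c2ccncc2)c1`, gives -15%, the highest of the three numbers. Compound 1, `O=C(Nc1cccc(-n2cc(-c3ccncc3)c(-c3cc(O)cc(Cl)c3)n2)c1)Nc1ccc(Cl)c(Cl)c1`, gives -38%, and compound 2, `COc1cc(Cl)cc(-c2nn(-c3cccc(NC(=O)Nc4cc(C(F)(F)F)cc(C(F)(F)F)c4)c3)cc2-c2ccncc2)c1`, gives -80%. Within the data shown here, the one measured step that differs in a single place, a number 23 percentage points higher from compound 1 to compound 3 (beyond the scatter), concerns a methyl in place of hydrogen on an oxygen and does not touch the part changed here.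

Compound 4, `COc1cc(Cl)cc(-c2nn(-c3cccc(NC(=O)c4cccc(C(F)(F)F)c4)c3)cc2-c2ccncc2)c1`, differs from compound 3 in one place: 3-(trifluoromethyl)phenyl in place of (3,4-dichlorophenyl)amino on a carbonyl carbon. Among the measured compounds shown here, no measured pair changes the carbonyl carbon in this way, so the size of the step cannot be read from a related step; only the three values give a frame. Compound 2 shows that a trifluoromethyl-bearing ring on this side can go with a strongly negative number, but it keeps the amino group that leaves here. The step from compound 3 to compound 4 is therefore expected to be small, a number 10 percentage points lower from compound 3 to compound 4 (within the scatter), with wide uncertainty. For compound 4 the estimated value is -25%, expected between -65% and 10%.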

Compound 4, a percentage reported as activity, at one concentration (the size of the read-out at that concentration, not a potency): 54%
The estimate for compound 4 lay 79 percentage points below the measured number; measured number above the stated range.
By their numbers in this assay, from the lowest: compound 2; then compound 1; then compound 3; then compound 4.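

In this assay, placing 3-(trifluoromethyl)phenyl on the carbonyl carbon in place of (3,4-dichlorophenyl)amino gives a number 69 percentage points higher from compound 3 to compound 4 (beyond the scatter), so the group at this position can strongly change the read-out, and here the change goes toward a weaker effect. The swap turns a urea into an amide and removes one hydrogen-bond donor, while the ring also trades two chlorines for a trifluoromethyl group, so several features change in a single step. Nothing available explains why the step is so large.

The compounds shown cannot separate the loss of the amino nitrogen from the change on the ring. As far as these compounds go, how the read-out would respond to a cyclohexyl ring or a carboxylic acid on this carbonyl carbon also remains open.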